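Compound 4: a cyanophenyl amide in the oxalamide series

The source may report more compounds than this note shows. Statements on the series, on what has been measured and on what is new or still open speak of the compounds shown alone.

In an assay on SK-OV-3 cells for inhibition of Indoleamine 2,3-dioxygenase 1 (Homo sapiens) (on this read-out lower numbers stand for stronger inhibition and higher numbers for weaker inhibition), compound 3 `O=C(Nc1ccc(Cl)cc1F)C(=O)N1CCC(c2ccnc3ccc(F)cc23)CC1` gives 7 nM, the lowest of the three numbers; compound 2 `O=C(Nc1ccc(Cl)cc1)C(=O)N1CCC(c2ccnc3ccc(F)cc23)CC1` gives 15 nM and compound 1 `NS(=O)(=O)NCCCNC(=O)/C(=N/O)Nc1ccc(F)c(Cl)c1`, a different scaffold, gives 1200 nM. Compound 4 `N#Cc1ccc(NC(=O)C(=O)N2CCC(c3ccnc4ccc(F)cc34)CC2)cc1` differs from compound 3 by 4-cyanophenyl in place of 4-chloro-2-fluorophenyl on an amide-type nitrogen. Among the measured compounds shown here, the only measured step on this aryl ring is a 2.1-fold lower number from compound 2 to compound 3 (0.33 log units; beyond the scatter); nothing measured bears on exchanging the chloro for a nitrile. Compound 4 loses that fluoro, so a step back toward the number of compound 2 is expected, and the unknown effect of the nitrile widens the range. For compound 4 the expected step is a 3.6-fold higher number from compound 3 to compound 4 (0.55 log units; beyond the scatter), giving an estimate of 25 nM with a range from 7 nM to 90 nM.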

Compound 4, half-maximal inhibitory concentration: 36 nM
The estimate for compound 4 lay 1.4-fold (0.16 log units) below the measured number, and the stated range covers the measured number.
By their numbers in this assay, from the lowest: compound 3; then compound 2; then compound 4; then compound 1.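

Among the compounds shown here, on the aryl ring, cyano in place of chloro on an aromatic carbon gives a 2.4-fold higher number from compound 2 to compound 4 (0.38 log units; beyond the scatter) and is the first measured exchange of the chloro. The full change on the amide-type nitrogen, which removes both chloro and fluoro, gives a 5.1-fold higher number from compound 3 to compound 4 (0.71 log units; beyond the scatter) and leaves both chloro-bearing rings with lower numbers than the 4-cyanophenyl ring. No measurement shown here explains either step.

Going by these compounds, whether a fluoro on the 4-cyanophenyl ring would repeat a 2.1-fold lower number from compound 2 to compound 3 (0.33 log units; beyond the scatter) stays open. So does how a methoxy or trifluoromethyl group would read in place of the nitrile.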